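Shifting the Furan Attachment Point on a Shared Core

A few compounds are considered here, and "the series" means these few. Any claim that something is new, unique, unknown or untested is made for them only; others in the source may bear on it.

Compound 1 is `Oc1ccccc1-c1cc(-c2cccs2)cc(-c2ccccc2O)n1`. In a functional assay on HCT-15 cells (Homo sapiens) for cytotoxicity, read by CCK-8 assay (a lower number here means a stronger inhibitor, a higher number a weaker inhibitor), compound 1 gives > 50000 nM, which is a limit of the assay rather than a number.
Compound 2 is `Oc1ccccc1-c1cc(-c2ccco2)cc(-c2ccccc2O)n1`. In this assay compound 2 gives > 50000 nM, again only a limit.

Compound 2 thus stands at the limit, as does compound 1; this is the limit of > 50000 nM in this assay, at which 2 of the 2 values shown sit. The step that the two limits leave unreadable from compound 1 to compound 2 is therefore not readable. Compound 3 is `Oc1ccccc1-c1cc(-c2ccoc2)cc(-c2ccccc2O)n1`. Compared with compound 2, the change is furan-3-yl in place of furan-2-yl on an aromatic carbon. Among the compounds with values here, the only measured step bearing on this change is the one from compound 1 to compound 2, and its size is unknown, so no direction or size beyond the scatter can be expected with confidence. Compound 3 is expected to sit at the same limit as compound 2. The estimate for compound 3 is 100000 nM, with a range from 30000 nM to 500000 nM. The step this estimate means is a step that the limit leaves unreadable from compound 2 to compound 3.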

Compound 3, half-maximal inhibitory concentration: > 50000 nM
Compound 3: only a limit was reported; the forecaster's own chance of this, stated with the estimate: 85%; the middle value lies beyond the limit too.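

No step can be read between compound 1, compound 2 and compound 3, because each value is only a limit: the limit of > 50000 nM in this assay, at which 3 of the 3 values shown sit.

The compounds shown leave open how strongly any of the three acts in this assay and whether thiophen-2-yl, furan-2-yl or furan-3-yl makes any difference there.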